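The source may hold more compounds than are shown below. What is called first, only, known or untested is meant among the compounds shown, and "the series" means these compounds.

Measured compounds in a functional assay on K562 cells (Homo sapiens) for cytotoxicity, read by MTT assay, with a stated time of 72 h; a lower number here means a stronger inhibitor, a higher number a weaker inhibitor:
compound 1 `c1ccc(NN=C(c2nc3ccccc3[nH]2)c2nc3ccccc3[nH]2)cc1` — 115000 nM
compound 2 `COc1ccc(NN=C(c2nc3ccccc3[nH]2)c2nc3ccccc3[nH]2)cc1` — 117000 nM
compound 3 `Clc1ccc(NN=C(c2nc3ccccc3[nH]2)c2nc3ccccc3[nH]2)cc1` — 200000 nM

The three compounds share one core and differ only in the group on the phenyl ring. Compound 3 carries the largest number of the three as read, but the steps of a 1.7-fold higher number from compound 1 to compound 3 (0.24 log units; within the scatter) and a 1.7-fold higher number from compound 2 to compound 3 (0.23 log units; within the scatter) both lie within the scatter, as does a 1.0-fold higher number from compound 1 to compound 2 (0.01 log units; within the scatter), so the three cannot be told apart in this assay.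

Compound 4 `O=[N+]([O-])c1ccc(NN=C(c2nc3ccccc3[nH]2)c2nc3ccccc3[nH]2)cc1` is the next member. The change from compound 3 is nitro in place of chloro on an aromatic carbon. Within the data shown here, no measured step swaps one substituent for a nitro group, so only the three steps above bear on it: hydrogen to methoxy, hydrogen to chloro and methoxy to chloro all left this assay unchanged beyond the scatter. Exchanging one substituent on this aromatic carbon for another has so far moved nothing, and the nitro group is expected to behave alike.

For compound 4 the expected step is a 1.2-fold lower number from compound 3 to compound 4 (0.07 log units; within the scatter), that is, no movement beyond the scatter. Compound 4 is therefore estimated at 170000 nM in this assay, with a range from 80000 nM to 350000 nM.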

Compound 4, half-maximal inhibitory concentration: 190000 nM
Compound 4: the middle estimate sits 1.1-fold (0.05 log units) below what was measured, within the range that was stated.
By their numbers in this assay, from the lowest: compounds 1, 2, 4 and 3 (each within the scatter of the next).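

On the aromatic carbon para to a large group, nitro joins hydrogen, methoxy and chloro as a fourth substituent that cannot be separated from the others in this assay: all three new steps (a 1.1-fold lower number from compound 3 to compound 4 (0.02 log units; within the scatter)), (a 1.6-fold higher number from compound 2 to compound 4 (0.21 log units; within the scatter)) and (a 1.7-fold higher number from compound 1 to compound 4 (0.22 log units; within the scatter)) stay within the scatter. Among these compounds, the series therefore remains flat at this position across compound 1, compound 2, compound 3 and compound 4, with no member going against that reading, and the change from 4-chlorophenyl to 4-nitrophenyl adds a further exchange that leaves the number where it was. No supporting measurement is available that would bear on why this position stays flat.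

From the compounds shown here alone, it remains open whether any group on this aromatic carbon can move the number in this assay beyond the scatter, for instance an amine, a carboxylic acid or a longer alkyl chain. Going by these compounds, it is equally open whether a change in the shared core, with the phenyl ring left unsubstituted, would shift the number where these substituent exchanges have not.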